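Lipoyl-triazole coumarin amides: cytotoxicity on PC-12 cells

The compounds below may be only part of what the source reports. "The series", "measured", "known", "first", "only" and "open" are said of these compounds alone.

Measured compounds:
- compound 1, `Cc1cc(=O)oc2cc(OCCCn3cc(CNC(=O)CCCCC4CCSS4)nn3)ccc12`, 69.4%
- compound 2, `CCOC(=O)c1cc2ccc(OCCCCCn3cc(CNC(=O)CCCCC4CCSS4)nn3)cc2oc1=O`, 38.3%
- compound 3, `O=C(CCCCC1CCSS1)NCc1cn(CCCCCOc2ccc3cc(-c4ccccc4)c(=O)oc3c2)nn1`, 26.3%

The three compounds share a lipoyl amide joined through a triazole and an alkoxy chain to a coumarin, and differ in the group on the coumarin ring. In a functional assay on PC-12 cells (Rattus norvegicus) for cytotoxicity, read by MTT assay, with stated times of 3 h and 2 h, tested at 10 uM (a higher number here means a stronger effect of the compound at the concentration tested, a lower number a weaker effect), compound 1 gives 69.4%, compound 2 gives 38.3% and compound 3 gives 26.3%. Compound 3 stands lowest of the three; its nearest neighbour is compound 2, its furthest compound 1. For the measured compounds named here, the only single-point step, a number 12 percentage points lower from compound 2 to compound 3 (beyond the scatter), concerns phenyl in place of ethoxycarbonyl on an aromatic carbon.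

Compound 4, `O=C(CCCCC1CCSS1)NCc1cn(CCCCCOc2ccc3cc(-c4ccc(Br)cc4)c(=O)oc3c2)nn1`, is not yet measured. It differs from compound 3 by bromo in place of hydrogen on an aromatic carbon, para to a large group on the phenyl ring. Going by the values given here, no measured step touches this change: the one step known is of a different kind and cannot be carried over. Among the compounds with values here, with no bearing step, a step within the scatter in this assay is expected, in no preferred direction; the estimated step is a number 1.7 percentage points higher from compound 3 to compound 4 (within the scatter). Compound 4 is therefore expected to give about 28%, with a range from 14% to 42%.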

Compound 4, a percentage reported as activity, at one concentration (the size of the read-out at that concentration, not a potency): 48.4%
For compound 4 the middle estimate is 20.4 percentage points below the measured one; the measured number lies above the stated range.
By their numbers in this assay, from the lowest: compound 3; then compound 2; then compound 4; then compound 1.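

In this assay, the only change shown on the phenyl ring itself already moves the read-out: with bromo on an aromatic carbon, para to a large group, the series records a number 22.1 percentage points higher from compound 3 to compound 4 (beyond the scatter), so this ring is not a silent part of the structure. The result also changes what the earlier step implied. Replacing ethoxycarbonyl with plain phenyl gave a number 12 percentage points lower from compound 2 to compound 3 (beyond the scatter), whereas replacing it with 4-bromophenyl gives a number 10.1 percentage points higher from compound 2 to compound 4 (beyond the scatter), so the direction of the replacement depends on the single bromo. No measurement at hand accounts for this rise.

Open, as far as these compounds go, is whether the rise belongs to bromo alone or would also appear with chloro, methoxy or an amine at the same place on the phenyl ring, and whether a bromo at another place on that ring would give a similar number. For the compounds shown here, also open is whether the step from phenyl to 4-bromophenyl holds on a shorter chain, such as the one in compound 1, or with a carboxylic acid in place of the phenyl group on the shared core.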